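Series notes: from compound 3 to compound 4

The source may hold more compounds than are shown below. What is called first, only, known or untested is meant among the compounds shown, and "the series" means these compounds.

Three compounds in the series have a reading in a functional assay on MOLT-4 cells (Homo sapiens) for inhibition, read by sulforhodamine B assay, with a stated time of 48 h; a higher number here means a weaker inhibitor of growth, a lower number a stronger inhibitor of growth. Compound 1 `O=C(Nc1cccc(-n2cc(-c3ccncc3)c(-c3ccc(Cl)c(O)c3)n2)c1)Nc1ccc(Cl)c(Cl)c1` gives 1380 nM. Compound 2 `COc1cc(-c2nn(-c3cccc(NC(=O)c4ccc(Cl)c(C(F)(F)F)c4)c3)cc2-c2ccncc2)ccc1Cl` gives 5240 nM. For the measured compounds named here, compound 3 `COc1cc(-c2nn(-c3cccc(NC(=O)c4cccc(C(F)(F)F)c4)c3)cc2-c2ccncc2)ccc1Cl` gives 2010 nM, which is the second highest of the three numbers; its gap to compound 1 is within the scatter, and it differs from compound 2 by a 2.6-fold lower number from compound 2 to compound 3 (0.42 log units; beyond the scatter), the only single-point step that has been measured.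

Compound 4 `COc1cc(-c2nn(-c3cccc(NC(=O)Nc4cccc(C(F)(F)F)c4)c3)cc2-c2ccncc2)ccc1Cl` has not yet been measured. It differs from compound 3 by (3-(trifluoromethyl)phenyl)amino in place of 3-(trifluoromethyl)phenyl on a carbonyl carbon. Compound 1 carries the same (3-(trifluoromethyl)phenyl)amino-type attachment on its carbonyl carbon, but it also differs from compound 3 in two further places, so it gives no clean reading on this change, and the step from compound 2 to compound 3 concerns a chloro on an aromatic carbon, not the carbonyl carbon. Going by the values given here, no measured step bears directly on the change.

The expectation for compound 4 is therefore a step of a 1.1-fold lower number from compound 3 to compound 4 (0.02 log units; within the scatter), that is, no move beyond the scatter in either direction. In this assay compound 4 is estimated at 1900 nM, with a range from 700 nM to 5000 nM.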

Compound 4, concentration for 50% growth inhibition: 936 nM
The estimate for compound 4 lay 2.0-fold (0.31 log units) above the measured number, within the range that was stated.
By their numbers in this assay, from the lowest: compounds 4, 1 and 3 (each within the scatter of the next, the first and the last beyond it); then compound 2.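

In this assay, the carbonyl carbon now has a measured response of its own: (3-(trifluoromethyl)phenyl)amino in place of 3-(trifluoromethyl)phenyl gives a 2.1-fold lower number from compound 3 to compound 4 (0.33 log units; beyond the scatter), so adding the nitrogen with its hydrogen-bond donor at this place moves growth inhibition in the stronger direction, by a modest step. Replacing 4-chloro-3-(trifluoromethyl)phenyl with the same (3-(trifluoromethyl)phenyl)amino group, which also removes the chloro, gives a 5.6-fold lower number from compound 2 to compound 4 (0.75 log units; beyond the scatter), the largest step measured so far in the series and one that places both changes in the same direction on this side of the molecule. No measurement at hand explains why either change lowers the number.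

The compounds shown leave open whether the response depends on the hydrogen of the added nitrogen, which a methylamino group or an ether oxygen on the same carbonyl carbon would test. They also leave open whether the step at the carbonyl carbon would keep its size with the chloro retained, as in a (4-chloro-3-(trifluoromethyl)phenyl)amino group, since compound 1 differs from compound 4 in more than one place.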